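The source may hold more compounds than are shown below. What is called first, only, known or untested is meant among the compounds shown, and "the series" means these compounds.

Measured compounds:
compound 1, `O=C(CCc1ccc(-c2ccccc2)cc1)c1ncc(-c2ccncc2)o1`, 2.3 nM
compound 2, `O=C(O)c1cccc(-c2cnc(C(O)CCc3ccc(-c4ccccc4)cc3)o2)n1`, 1100 nM

In an assay for inhibition of Fatty-acid amide hydrolase 1 (Rattus norvegicus) (a lower number here means a stronger inhibitor, a higher number a weaker inhibitor), compound 1 gives 2.3 nM, the lowest of the two numbers recorded. Among the compounds with values here, compound 2 gives 1100 nM in this assay, a far higher number than that of compound 1, well beyond the usual scatter; the two values are all that is known of the pair, since no single-point step connects them.

Compound 3, `NC(=O)c1ccc(-c2cnc(C(=O)CCc3ccc(-c4ccccc4)cc3)o2)nc1`, has not yet been measured in this assay. It is derived from compound 1 by one change: 5-carbamoylpyridin-2-yl in place of pyridin-4-yl on an aromatic carbon. Within the data shown here, no step between two measured compounds documents this exchange, so its effect can only be expected, not read off. Because compound 1 gives 2.3 nM, the ketone-bearing core is retained and the change is confined to the substituent on the aromatic carbon, the step from compound 1 to compound 3 is expected to be small, a 2.2-fold higher number from compound 1 to compound 3 (0.34 log units; beyond the scatter), and likely within the scatter. Compound 3 is accordingly estimated at 5 nM, with a range of 1.5 nM to 20 nM.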

Compound 3, inhibition constant: 1.3 nM
Estimate against measurement, compound 3: 3.8-fold (0.59 log units) above, and the stated range ends above it.
By their numbers in this assay, from the lowest: compounds 3 and 1 (each within the scatter of the next); then compound 2.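

In this assay, within the data shown here, placing 5-carbamoylpyridin-2-yl instead of pyridin-4-yl on the aromatic carbon next to the ring oxygen gives a 1.8-fold lower number from compound 1 to compound 3 (0.25 log units; within the scatter), the first single-place step at this position. The position therefore accepts the larger group, with its carbamoyl and its hydrogen-bond donor, without any change in this assay that can be told from the scatter. Nothing at hand gives a reason for this outcome.

On these data alone, it remains open what a plain pyridin-2-yl would give here, and likewise a carboxylic acid or a nitrile in place of the carbamoyl, so the carbamoyl and the different ring attachment cannot yet be separated. Also open, as far as these compounds go, is how a secondary alcohol in place of the carbonyl would read with either of these two aromatic groups.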